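This account rests on a few compounds, and the source may have more. Where it says the series, first, only, none or still open, it means among the compounds named here.

Measured so far:
- Compound 1, `CC(C)CCOC(=O)OCC(CO)CCn1cnc2cnc(N)nc21`, 144 h
- Compound 2, `CC(C)COC(=O)OCC(CO)CCn1cnc2cnc(N)nc21`, 192 h
- Compound 3, `CC(C)OC(=O)OCC(CO)CCn1cnc2cnc(N)nc21`, 624 h

These three share one core and differ only in the alkyl group on the carbonate oxygen. In an ADME assay for pharmacokinetics, read by HPLC, in phosphate buffer, at 37 degrees C, at pH 8 (a lower number here means that the compound disappears faster, a higher number that the compound lasts longer), compound 2 stands second highest of the three: its nearest neighbour is compound 1, and a 1.3-fold higher number from compound 1 to compound 2 (0.12 log units; within the scatter), a gap that does not count as a real difference; the furthest is compound 3, and a 3.3-fold higher number from compound 2 to compound 3 (0.51 log units; beyond the scatter).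

Compound 4, `CCCCOC(=O)OCC(CO)CCn1cnc2cnc(N)nc21`, has not yet been measured. It is built from compound 2 by a rearrangement of the same atoms: propyl in place of isopropyl on a saturated chain carbon bound to an oxygen next to a carbonyl group. In other words, the branched isobutyl becomes a straight butyl chain.

For the measured compounds named here, two measured steps bear on this. Going from a branched four-carbon group to the more compact isopropyl gave a 3.3-fold higher number from compound 2 to compound 3 (0.51 log units; beyond the scatter), while lengthening the branched chain gave a 1.3-fold higher number from compound 1 to compound 2 (0.12 log units; within the scatter). Neither step is the same as straightening the chain, so the guide is loose. Compound 2 and compound 1 show that changes at the far end of the chain move the number little, so a step of a 1.3-fold lower number from compound 2 to compound 4 (0.11 log units; within the scatter) is expected, most likely within the scatter. Compound 4 is therefore estimated at 150 h, with a range from 80 h to 300 h.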

Compound 4, half-life: 120 h
For compound 4 the middle estimate is 1.3-fold (0.10 log units) above the measured one; the measured number falls inside the stated range.
By their numbers in this assay, from the lowest: compounds 4, 1 and 2 (each within the scatter of the next); then compound 3.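

Rearranging the same atoms, with propyl in place of isopropyl on a saturated chain carbon bound to an oxygen next to a carbonyl group, gives a 1.6-fold lower number from compound 2 to compound 4 (0.20 log units; within the scatter) in this assay, so straightening the chain at this position has no effect that can be told from the scatter. Likewise, the result is a 1.2-fold lower number from compound 1 to compound 4 (0.08 log units; within the scatter), which makes the butyl, isobutyl and isopentyl carbonates indistinguishable here, while a 5.2-fold lower number from compound 3 to compound 4 (0.72 log units; beyond the scatter) leaves compound 3, with its isopropyl group, as the only one of the four that stands apart. No measurement shown here explains why the isopropyl carbonate separates from the other three.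

The compounds shown leave open whether the higher number belongs to isopropyl in particular or would also appear with a shorter chain such as ethyl or methyl, or with a more heavily branched group such as tert-butyl. They also leave open whether a cyclopropyl ring or a longer chain such as hexyl on the same oxygen would stay with the butyl group of compound 4 or move toward compound 3.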